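This account rests on a few compounds, and the source may have more. Where it says the series, first, only, none or still open, it means among the compounds named here.

Measured compounds in hand:

- compound 1, `CO/N=C(\CCN1CCN(c2ccccn2)CC1)c1ccc(Cl)cc1`, in a functional assay on HEK293 cells with D(4) dopamine receptor (Homo sapiens) as the target, read by FLIPR (a lower number here means that less compound is needed, a higher number that more compound is needed for the effect), gives 37.6 nM
- compound 2, `CO/N=C(/CCN1CCN(c2ccccn2)CC1)c1ccc(Cl)cc1`, in this assay gives 56.6 nM
- compound 3, `CO/N=C(\c1ccc(Cl)cc1)C(O)CN1CCN(c2ccccn2)CC1`, in this assay gives 46 nM

Compound 3 stands second highest of the three numbers. Its nearest neighbour is compound 1, and the gap between them is within the scatter; the gap to compound 2 is within the scatter as well, so no order among the three can be read from these numbers.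

Compound 4, `CO/N=C(/c1ccc(Cl)cc1)C(O)CN1CCN(c2ccccn2)CC1`, differs from compound 3 only in drawn configuration: the two compounds have the same atoms and bonds; at least one stereo element is drawn with a configuration in one of them and without one in the other: 1 of 2 stereo elements differ; a double bond is drawn E in compound 3 and Z in compound 4. Going by the values given here, the one measured step that bears on this is the step from compound 1 to compound 2, which is the same kind of change, the double bond redrawn from E to Z: a 1.5-fold higher number from compound 1 to compound 2 (0.18 log units; within the scatter). That the two compounds differ only in configuration as drawn the fact that compounds 1 and 2 differ only in the configuration as drawn makes this the closest available comparison.

On that basis the step from compound 3 to compound 4 is expected to be a 1.3-fold higher number from compound 3 to compound 4 (0.12 log units; within the scatter), with no movement beyond the scatter. Compound 4 is estimated at 60 nM, in the range 30 nM to 120 nM.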

Compound 4, half-maximal effective concentration: 22.6 nM
Beside the measured number, compound 4's estimate is 2.7-fold (0.42 log units) above it; measured number below the stated range.
By their numbers in this assay, from the lowest: compounds 4, 1, 3 and 2 (each within the scatter of the next, the first and the last beyond it).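

In this assay, with hydroxy on the chain, redrawing the double bond from E to Z gives a 2.0-fold lower number from compound 3 to compound 4 (0.31 log units; beyond the scatter); this is a modest step, but unlike the same redrawing without hydroxy, it lies beyond the scatter. The hydroxy exchange with this double bond configuration gives a 1.7-fold lower number from compound 1 to compound 4 (0.22 log units; within the scatter), so at this chain carbon the exchange stays within the scatter on both cores. The configuration at the double bond therefore shows more of a difference here than hydroxy in place of hydrogen, although the comparison carries a caveat about how the stereochemistry is drawn: the fact that one of compounds 3 and 4 is drawn with a defined configuration and the other without, at the place where they differ.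

On these data alone, whether the double bond step holds with another group on that chain carbon, such as an amine or a methoxy group, remains open. So does whether the two configurations of the hydroxy-bearing carbon differ in this assay.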